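The compounds below may be only part of what the source reports. "The series", "measured", "known", "first", "only" and "open" are said of these compounds alone.

Working notes on the series in a functional assay on HCT-116 cells (Homo sapiens) for antiproliferative activity, with a stated time of 48 h; on this read-out higher numbers stand for weaker inhibition and lower numbers for stronger inhibition. Compound 1 (`CC(=O)c1ccc(-c2ccc(N3CCCC3)nn2)cc1`) reads > 25000 nM, which is a limit of the assay. Compound 2 (`CCN(CC)c1ccc(-c2ccc(C#N)cc2)nn1`) reads > 25000 nM, also a limit. Among the compounds with values here, compound 3 (`CCN(CC)c1ccc(-c2ccc(C(=O)OC)cc2)nn1`) gives 60 nM, the only actual number so far. Compound 4 (`CCOC(=O)c1ccc(-c2ccc(N(CC)CC)nn2)cc1`) differs from compound 3 by methyl in place of hydrogen on a saturated chain carbon bound to an oxygen next to a carbonyl group, that is, methoxycarbonyl to ethoxycarbonyl. Within the data shown here, the one measured step bearing on this is an at least 410-fold lower number from compound 2 to compound 3 (2.61 log units; beyond the scatter), a large step at the same substituent. It replaces cyano outright, so the far smaller change here should move the number much less. The estimated change is a 1.5-fold higher number from compound 3 to compound 4 (0.18 log units; within the scatter), modest and toward weaker inhibition. For compound 4 the estimate is 90 nM, with an expected range of 25 nM to 400 nM.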

Compound 4, half-maximal inhibitory concentration: 500 nM
Compound 4: middle estimate off by 5.6-fold (0.74 log units), on the low side, outside the stated range (above it).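

Even the smallest change at this position counts: going from methoxycarbonyl to ethoxycarbonyl, one added methyl on a saturated chain carbon bound to an oxygen next to a carbonyl group gives an 8.3-fold higher number from compound 3 to compound 4 (0.92 log units; beyond the scatter). Ethoxycarbonyl still stands well clear of cyano, with an at least 50-fold lower number from compound 2 to compound 4 (1.69 log units; beyond the scatter). That step is only a bound, as compound 2 reads as a limit of the assay: the limit of > 25000 nM in this assay, at which 2 of the 4 values shown sit.

Two groups give one step and no trend. On these data alone, whether a longer chain such as propoxycarbonyl weakens inhibition further, and how a carboxylic acid at the same aromatic carbon reads, stay open.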